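Trifluoropropyl in place of cyclopentyl on the shared core

The source may hold more compounds than are shown below. What is called first, only, known or untested is meant among the compounds shown, and "the series" means these compounds.

Measured so far in an ADME assay on microsomes from liver (Mus musculus) for metabolic stability, with a stated time of 30 min, tested at 1 uM; a lower number here means that less of the compound is left, a higher number that more of the compound is left:
Compound 1 `CC[C@@H]1C(=O)N(C)c2cnc(-n3ccnc3-c3ccccc3)nc2N1C1CCCC1` gives 0%.
Compound 2 `CCC1C(=O)N(C)c2cnc(-n3ccnc3-c3ccc(F)cc3)nc2N1C1CCC(F)(F)C1` gives 15%.
Compound 3 `CC[C@@H]1C(=O)N(C)c2cnc(-c3cn[nH]c3-c3ccc(F)cc3F)nc2N1c1cnn(C)c1` gives 5%.

Of the three numbers, compound 1 has the lowest. Its nearest neighbour is compound 3, whose number lies within the usual scatter, so these two cannot be told apart on this evidence. The furthest is compound 2, whose number lies beyond the scatter above compound 1. The three compounds differ from one another in more than one place, so none of these gaps can be tied to a single structural change.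

Compound 4 `CC[C@@H]1C(=O)N(C)c2cnc(-n3ccnc3-c3ccccc3)nc2N1CCC(F)(F)F` has not yet been measured. It differs from compound 1 in one place:
3,3,3-trifluoropropyl in place of cyclopentyl on a nitrogen on an aromatic ring in a ring

Among the compounds with values here, no measured pair differs in only one place, so there is no measured step to lean on for this change. With compound 1 at the bottom of the range seen, the step of a number 10 percentage points higher from compound 1 to compound 4 (within the scatter) is expected to be small and upward, most likely within the scatter rather than beyond it. Compound 4 is therefore expected to give roughly 10% in this assay, with an estimated range from 0% to 30%.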

Compound 4, percent of the compound remaining: 2%
Beside the measured number, compound 4's estimate is 8 percentage points above it, within the range that was stated.
By their numbers in this assay, from the lowest: compounds 1, 4, 3 and 2 (each within the scatter of the next, the first and the last beyond it).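

In this assay, within the data shown here, 3,3,3-trifluoropropyl in place of cyclopentyl on this nitrogen gives a number 2 percentage points higher from compound 1 to compound 4 (within the scatter), the first step in this set that can be tied to a single structural change. The two compounds cannot be told apart, so on this evidence, exchanging a five-membered ring of carbon only for an open chain carrying fluorine has no readable effect on how much of the compound is left. Nothing available here explains this result. 

As far as these compounds go, it remains open whether another group on this nitrogen, such as a cyclohexyl ring or a chain ending in an amine, would shift the number beyond the scatter. Also open, from the compounds shown here alone, is whether 3,3,3-trifluoropropyl would give a similarly small step on a compound that starts from a higher number, such as compound 2 at 15%, where the group on this nitrogen and the substituted phenyl both differ from those in compound 1.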